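Amide substituent variation on the shared core

This account rests on a few compounds, and the source may have more. Where it says the series, first, only, none or still open, it means among the compounds named here.

In a functional assay on the whole organism for inhibition, with Rattus norvegicus as the target, read by paw edema, with stated times of 30 min and 2 h, at a dose of 0.28 mmol/kg by the oral route (on this read-out lower numbers stand for less inhibition and higher numbers for more inhibition at the one dose given (going by the name of the read-out)), compound 1 `CCNC(=O)c1nc(-c2cc(OC)c(OC)c(OC)c2)n(-c2ccc(OC)cc2)n1` gives 68%. Within the data shown here, compound 2 `COc1ccc(NC(=O)c2nc(-c3cc(OC)c(OC)c(OC)c3)n(-c3ccc(OC)cc3)n2)cc1` carries 4-methoxyphenyl in place of ethyl on the amide-type nitrogen, and in this assay compound 2 gives 45%; the step of a number 23 percentage points lower from compound 1 to compound 2 (beyond the scatter) lies beyond the scatter, so compound 2 stands lowest of the two numbers measured so far. Compound 3 `COc1ccc(-n2nc(C(=O)Nc3ccccc3OC)nc2-c2cc(OC)c(OC)c(OC)c2)cc1` differs from compound 2 in one place: 2-methoxyphenyl in place of 4-methoxyphenyl on an amide-type nitrogen. Among the measured compounds shown here, no measured step concerns a change of this kind on the amide substituent; the one step recorded, a number 23 percentage points lower from compound 1 to compound 2 (beyond the scatter), exchanges ethyl for 4-methoxyphenyl and gives no guide to moving the methoxy group within the aryl ring. With nothing to set a direction, for compound 3 the step of no change at the digits printed from compound 2 to compound 3 (within the scatter) is expected to lie within the scatter. Compound 3 is therefore estimated at 45% in this assay, within 30% to 60%.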

Compound 3, a percentage reported as inhibition, in the whole organism at one dose (the size of the read-out at that dose, not a potency): 57%
Compound 3: middle estimate off by 12 percentage points, on the low side; the measured number falls inside the stated range.
By their numbers in this assay, from the lowest: compound 2; then compound 3; then compound 1.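

In this assay, moving the methoxy group within the aryl ring on the amide-type nitrogen is a change that can be read: 2-methoxyphenyl in place of 4-methoxyphenyl gives a number 12 percentage points higher from compound 2 to compound 3 (beyond the scatter), although the two groups have the same atoms. The aryl-for-ethyl exchange therefore does not have one fixed size, yet 2-methoxyphenyl still falls short of ethyl, with a number 11 percentage points lower from compound 1 to compound 3 (beyond the scatter), and ethyl remains the best of the three groups at this position. Nothing measured on these compounds accounts for the difference between the two methoxyphenyl groups.

Going by these compounds, whether an unsubstituted phenyl would fall with the methoxyphenyl amides or nearer the ethyl amide remains open. Also open, on these data alone, is how a longer chain such as butyl, or a benzyl group, would compare with ethyl on this nitrogen.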